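A few compounds are considered here, and "the series" means these few. Any claim that something is new, unique, unknown or untested is made for them only; others in the source may bear on it.

Measured so far:
- Compound 1, `CCCC/C(=C\C=C\C(=O)N[C@H](C)CCCc1cccnc1)c1ccc(OC)cc1`: 0.68 mg/kg
- Compound 2, `O=C(/C=C/C=C(c1cccc(F)c1)c1cccc(F)c1)NCCCCc1cccnc1`: 0.34 mg/kg

Both compounds were tested in a functional assay with platelet-activating factor receptor (Cavia porcellus) as the target; on this read-out higher numbers stand for an effect only at larger amounts of compound and lower numbers for an effect already at smaller amounts. Compound 1 gives 0.68 mg/kg and compound 2 gives 0.34 mg/kg. The number for compound 1 is the higher of the two, but the distance to compound 2 lies within the usual scatter of repeated measurements, so the two compounds cannot be told apart on this assay.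

Compound 3, `COc1ccc(/C(=C/C=C/C(=O)N[C@H](C)CCCc2cccnc2)C(C)C)cc1`, has not yet been measured. It differs from compound 1 in one place: isopropyl in place of butyl on a double-bonded chain carbon bound to an aromatic carbon and a double-bonded chain carbon. The amide chain, the pyridine-bearing side chain and the methoxy-bearing aromatic ring are unchanged.

Among the measured compounds shown here, no measured pair shows what swapping one small alkyl group for another does here, so there is no step to lean on. The change removes one carbon from a short branchless chain and rearranges the remainder into a branched group. With nothing in the data pointing one way or the other, the expectation is a step from compound 1 to compound 3 of a 1.0-fold higher number from compound 1 to compound 3 (0.01 log units; within the scatter), that is, none beyond the scatter. Compound 3 is therefore expected to give about 0.7 mg/kg in this assay, within a range from 0.3 mg/kg to 1.6 mg/kg.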

Compound 3, dose for 50% inhibition: 0.41 mg/kg
Compound 3: middle estimate off by 1.7-fold (0.23 log units), on the high side; low and high end bracket the measured number.
By their numbers in this assay, from the lowest: compounds 2, 3 and 1 (each within the scatter of the next).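

In this assay, among the compounds shown here, putting isopropyl in place of butyl on a double-bonded chain carbon bound to an aromatic carbon and a double-bonded chain carbon gives a 1.7-fold lower number from compound 1 to compound 3 (0.22 log units; within the scatter), and this is the only step so far that isolates a single change. At this position, then, butyl with its 4 carbons and the branched isopropyl with its 3 carbons cannot be told apart on this read-out, so this particular change in the shape and size of a small alkyl group leaves no mark beyond the ordinary spread of repeated measurements. No measurement at hand offers a reason for this outcome.

Going by these compounds, one exchange between two small alkyl groups says little about the position as a whole, and it remains open whether methyl, a longer chain such as octyl, a cyclopropyl ring, or a group carrying an amine or a carboxylic acid would shift the number beyond the scatter. Compound 2 differs from compound 1 and compound 3 in more than one place, so it cannot show whether the same holds on its scaffold.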